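From tert-butyl to amino on the aromatic ring

The source may hold more compounds than are shown below. What is called first, only, known or untested is meant among the compounds shown, and "the series" means these compounds.

Of the compounds shown here, three sharing one core have been measured so far in an ADME assay on MRC5 cells (Homo sapiens) for cytotoxicity, read by fluorescence, with a stated time of 24 h (on this read-out higher numbers stand for weaker inhibition and lower numbers for stronger inhibition), on this scale. Compound 1 (`O=C(N/N=C/c1ccc2no[n+]([O-])c2c1)c1ccccc1`) gives 130000 nM there, compound 2 (`Nc1cccc(C(=O)N/N=C/c2ccc3no[n+]([O-])c3c2)c1`) gives 82100 nM there, and compound 3 (`CC(C)(C)c1ccc(C(=O)N/N=C/c2ccc3no[n+]([O-])c3c2)cc1`) gives 25200 nM there, the lowest of the three numbers.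

The next compound is compound 4 (`Nc1ccc(C(=O)N/N=C/c2ccc3no[n+]([O-])c3c2)cc1`), which has amino in place of tert-butyl on an aromatic carbon, para to a large group (amino in place of tert-butyl on an aromatic carbon).

Among the compounds with values here, two measured steps bear on this change. Adding tert-butyl in place of hydrogen gave a 5.2-fold lower number from compound 1 to compound 3 (0.71 log units; beyond the scatter) and this modest step lies beyond the scatter. Adding amino in place of hydrogen gave a 1.6-fold lower number from compound 1 to compound 2 (0.20 log units; within the scatter) and this step lies within the scatter, although the amino of compound 2 sits on a different aromatic carbon from that of compound 4. Within the data shown here, no measurement yet tests amino at the new place. Losing tert-butyl is therefore expected to undo most of the first step, while amino is expected to add little. The expected move in this assay is a 3.2-fold higher number from compound 3 to compound 4 (0.50 log units; beyond the scatter) overall, a modest rise. For compound 4 the estimated value is 80000 nM with a likely span from 35000 nM to 170000 nM around it.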

Compound 4, half-maximal inhibitory concentration in the MRC5 assay: 841000 nM
Beside the measured number, compound 4's estimate is 11-fold (1.02 log units) below it; the whole stated range lies below it.
By their numbers in the MRC5 assay, from the lowest: compound 3; then compounds 2 and 1 (each within the scatter of the next); then compound 4.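

In the MRC5 assay, amino at this place does more than lose what tert-butyl had gained, giving a 33-fold higher number from compound 3 to compound 4 (1.52 log units; beyond the scatter), and the number ends up on the weaker side of the unsubstituted parent, with a 6.5-fold higher number from compound 1 to compound 4 (0.81 log units; beyond the scatter). So amino is not a silent group here, and its carbon on the ring matters: moving it from the other carbon of compound 2, in the change from 3-aminophenyl to 4-aminophenyl, gives a 10-fold higher number from compound 2 to compound 4 (1.01 log units; beyond the scatter), although amino at that other carbon had left the number within the scatter of the parent, with a 1.6-fold lower number from compound 1 to compound 2 (0.20 log units; within the scatter). The weaker cytotoxicity of compound 4 comes with a large fall in lipophilicity relative to compound 3, a link that rests on this one pair: the measured partition coefficient of compound 3, 3.8, and of compound 4, 1.2, a number 2.60 log units lower (beyond the scatter).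

From the compounds shown here alone, whether the rise belongs to amino itself or would follow other groups at the same place stays open, and a hydroxyl, a methyl or a carboxylic acid there would help to tell. In a physicochemical assay for lipophilicity, read by HPLC, measured as octanol-water partition (on this read-out higher numbers stand for higher lipophilicity and lower numbers for lower lipophilicity), compound 3 gives 3.8 and compound 4 gives 1.2. With partition coefficients given only for compound 3 and compound 4, the compounds shown also cannot say whether lipophilicity follows the numbers across all four.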